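Swapping the aryl ketone for a cyclopropyl ketone

The source may hold more compounds than are shown below. What is called first, only, known or untested is meant among the compounds shown, and "the series" means these compounds.

Compound 1 `O=C(/C=C\N(O)Cc1ccc2ccccc2c1)c1ccc(F)cc1` stands lowest of the two numbers measured in an assay on RBL-1 cells for inhibition of Polyunsaturated fatty acid 5-lipoxygenase (Rattus norvegicus) (a lower number here means a stronger inhibitor, a higher number a weaker inhibitor), where compound 1 gives 400 nM; its nearest neighbour, compound 2 `CCCCCCCCCCN(O)/C=C\C(=O)c1ccc(F)cc1`, gives 13000 nM in this assay, a gap beyond the scatter. Compound 3 `O=C(/C=C\N(O)Cc1ccc2ccccc2c1)C1CC1` has not been measured; it differs from compound 1 by cyclopropyl in place of 4-fluorophenyl on a carbonyl carbon. Among the measured compounds shown here, no measured pair shows this change, so its size is unknown. Loss of the aromatic ring on the carbonyl is expected to weaken inhibition somewhat, a step of a 3.0-fold higher number from compound 1 to compound 3 (0.48 log units; beyond the scatter) of modest size. Compound 3 is therefore estimated at 1200 nM, within 300 nM to 5000 nM.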

Compound 3, half-maximal inhibitory concentration: 1500 nM
For compound 3 the middle estimate is 1.3-fold (0.10 log units) below the measured one; the measured number falls inside the stated range.
By their numbers in this assay, from the lowest: compound 1; then compound 3; then compound 2.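

In this assay, this is the first change shown at the carbonyl carbon, and it gives a 3.8-fold higher number from compound 1 to compound 3 (0.57 log units; beyond the scatter). Inhibition therefore survives without the 4-fluorophenyl, since cyclopropyl retains much of it, although the replacement carries a modest cost. Nothing available explains the size of this step.

From the compounds shown here alone, whether the difference tracks the aromatic ring or the fluorine stays open, since an unsubstituted phenyl on the same carbonyl carbon would separate the two. Going by these compounds, it also remains open how a pyridine ring or a tert-butyl group would compare there.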